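Carbonyl substituent variation in a two-compound series

The source may report more compounds than this note shows. Statements on the series, on what has been measured and on what is new or still open speak of the compounds shown alone.

Measured so far:
Compound 1: `CCCOC(=O)C1=C(C)NC(=O)NC1c1ccco1`, 3%
Compound 2: `CCNC(=O)C1=C(C)NC(=O)NC1c1ccco1`, 3%

In an assay on membranes from HeLa cells for displacement of a labelled ligand from adenosine receptor A3 (Homo sapiens), read by scintillation counting, with a stated time of 180 min, tested at 1 uM (on this read-out lower numbers stand for less inhibition and higher numbers for more inhibition at the one concentration tested (going by the name of the read-out)), compound 1 gives 3%. In this assay compound 2 gives 3%. Going by the values given here, the single measured step, no change at the digits printed from compound 1 to compound 2 (within the scatter), replaces propoxy with ethylamino on a carbonyl carbon and shows nothing beyond the scatter; compound 2 therefore stands level with compound 1 at the digits known, and neither compound shows meaningful inhibition at the concentration tested.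

Compound 3, `CC1=C(C(=O)NC(C)C)C(c2ccco2)NC(=O)N1`, differs from compound 2 by methyl in place of hydrogen on a saturated chain carbon bound to an amide-type nitrogen and a saturated chain carbon. Among the compounds with values here, the only step that bears on it is no change at the digits printed from compound 1 to compound 2 (within the scatter), which also altered the group on the carbonyl carbon and gave no change within the scatter. Since that larger change left the read-out flat, no step beyond the scatter is expected for the smaller change here: the estimated a number 1 percentage points higher from compound 2 to compound 3 (within the scatter) is essentially nil. Compound 3 is expected to give 4% in this assay, with a range of -8% to 16%.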

Compound 3, a percentage reported as inhibition, at one concentration (the size of the read-out at that concentration, not a potency): 4%
Estimate against measurement, compound 3: no gap at the digits printed, within the range that was stated.
By their numbers in this assay, from the lowest: compounds 1, 2 and 3 (each within the scatter of the next).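

In this assay, methyl in place of hydrogen on a saturated chain carbon bound to an amide-type nitrogen and a saturated chain carbon, which turns ethylamino into isopropylamino, gives a number 1 percentage points higher from compound 2 to compound 3 (within the scatter), so this first test of branching on the amide side shows no effect that can be separated from the scatter. Exchanging the propoxy group on the carbonyl carbon for isopropylamino gives a number 1 percentage points higher from compound 1 to compound 3 (within the scatter), so the branched amide is not distinguished from the propyl ester either. Nothing available explains why the read-out stays flat across these changes.

On these data alone, whether a carboxylic acid, a benzylamino group or a longer chain such as butylamino on the carbonyl carbon would move the read-out beyond the scatter remains open. As far as these compounds go, with all three compounds giving little inhibition, it also remains open whether ethylamino and isopropylamino would differ on a more strongly inhibiting compound.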